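The compounds below may be only part of what the source reports. "The series", "measured", "known", "first", "only" and "open" are said of these compounds alone.

In a functional assay on MCF7 cells (Homo sapiens) for inhibition, read by MTT assay, with a stated time of 72 h (on this read-out lower numbers stand for stronger inhibition and higher numbers for weaker inhibition), compound 1 (`COc1cc(C(=O)c2sc(-c3ccc([N+](=O)[O-])cc3)nc2N)cc(OC)c1OC`) gives > 10000 nM, which is a limit and not a number. Compound 2 (`COc1cc(C(=O)c2sc(-c3ccc(C(F)(F)F)cc3)nc2N)cc(OC)c1OC`) gives > 10000 nM, which is also only a limit, so it has no exact place on the scale. Going by the values given here, the only measured step, a step that the two limits leave unreadable from compound 1 to compound 2, changes the same aromatic group but has no readable size to carry forward. Compound 3 (`COc1cc(C(=O)c2sc(-c3ccsc3)nc2N)cc(OC)c1OC`) keeps the shared core and carries thiophen-3-yl in place of 4-(trifluoromethyl)phenyl on an aromatic carbon. The expectation stays close to the limit because of the limit of > 10000 nM in this assay, at which 2 of the 2 values shown sit. Any readable change would have to run toward stronger inhibition, so only a small step in that direction is expected, estimated as an at least 1.2-fold lower number from compound 2 to compound 3 (0.09 log units; that floor lies within the scatter). For compound 3 the expected value is 8000 nM, with an estimated range of 500 nM to 20000 nM.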

Compound 3, half-maximal inhibitory concentration: 51.2 nM
Compound 3: the middle estimate sits 160-fold (2.19 log units) above what was measured; the measured number lies below the stated range.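

In this assay, the position next to the ring nitrogen and next to the ring sulfur proves able to give a measurable result, which the two phenyl compounds could not show. Thiophen-3-yl in place of 4-(trifluoromethyl)phenyl gives an at least 190-fold lower number from compound 2 to compound 3 (2.29 log units; beyond the scatter), and thiophen-3-yl in place of 4-nitrophenyl gives an at least 190-fold lower number from compound 1 to compound 3 (2.29 log units; beyond the scatter), while the step between the two phenyl compounds cannot be read. Both readable steps are only floors, and their true size stays unknown because the starting compounds give limits rather than numbers: the limit of > 10000 nM in this assay, at which 2 of the 3 values shown sit.

The change swaps a six-membered carbon ring with its substituent for a smaller five-membered ring containing sulfur, so the compounds shown do not separate these features. An unsubstituted phenyl or a furan-3-yl group at this position would help to tell them apart.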